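Adding an Amino Group to a Sub-Nanomolar Kinase Inhibitor

The source may hold more compounds than are shown below. What is called first, only, known or untested is meant among the compounds shown, and "the series" means these compounds.

Of the compounds shown here, two have so far been measured in an assay on isolated protein for binding affinity to Leucine-rich repeat serine/threonine-protein kinase 2 (Homo sapiens), read by TR-FRET and LanthaScreen, with a stated time of 2 h; a higher number here means a weaker inhibitor, a lower number a stronger inhibitor. Compound 1 `Cc1c(Nc2nc(N)c3c(C#N)c(N4CCC[C@H]4C)n(C)c3n2)cnn1C` gives 2 nM in this assay. Compound 2 `C[C@@H]1CCCN1c1c(C#N)c2c(N)ncnc2n1C` keeps the shared core but carries a hydrogen where compound 1 carries the (1,5-dimethyl-1H-pyrazol-4-yl)amino group, and in this assay compound 2 gives 0.4 nM. Among the compounds with values here, that change is the only step measured: a 5.0-fold lower number from compound 1 to compound 2 (0.70 log units; beyond the scatter). Compound 2 thus stands lowest of the two numbers, with compound 1 the nearest and beyond the scatter above it.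

Compound 3 `C[C@@H]1CCCN1c1c(C#N)c2c(N)nc(N)nc2n1C` differs from compound 2 by one change: amino in place of hydrogen on an aromatic carbon. Within the data shown here, the amino group enters the very position where compound 1 carried its much larger substituted amino group, so the step from compound 1 to compound 2 is the only measured step that bears on it. Removing the large group lowered the number by a modest amount; putting back a single nitrogen is a far smaller change, so only a small step, if any, is expected here, with no clear direction beyond the scatter. For compound 3 the expected value in this assay is 0.6 nM, with a range from 0.2 nM to 2 nM. This estimate corresponds to an expected step of a 1.5-fold higher number from compound 2 to compound 3 (0.18 log units; within the scatter).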

Compound 3, inhibition constant: 6 nM
The estimate for compound 3 lay 10-fold (1.00 log units) below the measured number; measured number outside the range, above it.
By their numbers in this assay, from the lowest: compound 2; then compound 1; then compound 3.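

In this assay, a single amino group on the aromatic carbon between two ring nitrogen atoms proves far from a minor change, giving a 15-fold higher number from compound 2 to compound 3 (1.18 log units; beyond the scatter), so at this position even one added nitrogen atom can shift the number by a large amount. The three compounds also do not line up by the size of the group: compound 3, with the small amino group, has the highest number, while the larger substituted amino group of compound 1 sits between hydrogen and amino, and the comparison of the two amino compounds gives a 3.0-fold higher number from compound 1 to compound 3 (0.48 log units; beyond the scatter). Hanging a 1,5-dimethyl-1H-pyrazol-4-yl group on that amino nitrogen therefore wins back part of what the bare amino group costs, but no measurement at hand says why the bare amino group raises the number.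

Still open, from the compounds shown here alone, is whether any atom in place of hydrogen raises the number or whether this is specific to a free amino group, which a methyl group or a chlorine atom at the same carbon would help to separate. A methylamino group or a phenylamino group there would show how much of the recovery seen in compound 1 needs the pyrazole ring itself.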